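The source may hold more compounds than are shown below. What is called first, only, known or untested is meant among the compounds shown, and "the series" means these compounds.

Measured in a functional assay on MDA-MB-231 cells (Homo sapiens) for antiproliferative activity, read by MTT assay, with a stated time of 24 h; a lower number here means a stronger inhibitor, a higher number a weaker inhibitor:
- compound 1 `O=C(NNc1cccc(Cl)c1)c1ccc(NS(=O)(=O)c2cnc(O)nc2O)cc1`: 17400 nM
- compound 2 `O=C(NNc1ccc(F)cc1)c1cccc(NS(=O)(=O)c2cnc(O)nc2O)c1`: > 20000 nM

Compound 2 stands at > 20000 nM in this assay, and this is a limit of the assay, not a number.

The next compound is compound 3 `O=C(NNC(=O)c1cccc(NS(=O)(=O)c2cnc(O)nc2O)c1)c1ccc(F)cc1`. It carries (4-fluorophenyl)carbonyl in place of the 4-fluorophenyl of compound 2 on an amine nitrogen ((4-fluorophenyl)carbonyl in place of 4-fluorophenyl on an amine nitrogen).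

Among the measured compounds shown here, no two measured compounds differ in one place, so the series gives no direct guide to this change. For the measured compounds named here, the only true number in this assay is that of compound 1, at 17400 nM. No shift beyond the scatter is expected in either direction, and the estimated step is a number no higher from compound 2 to compound 3 (the limit leaves the size open). For compound 3 the expected value is 20000 nM, with an estimated range of 9000 nM to 45000 nM.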

Compound 3, half-maximal inhibitory concentration: > 20000 nM
Compound 3: no number, only a limit; the forecaster's own chance of this, stated with the estimate: 55%; the middle value lies on the limit itself.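

Compound 2 and compound 3 both stand at a limit and not at a number, and no step between them can be read: the limit of > 20000 nM in this assay, at which 2 of the 3 values shown sit.

The compounds shown leave open whether (4-fluorophenyl)carbonyl in place of 4-fluorophenyl on an amine nitrogen changes antiproliferative activity at all.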